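This account rests on a few compounds, and the source may have more. Where it says the series, first, only, none or still open, it means among the compounds named here.

Working notes on the series, read in a physicochemical assay for lipophilicity; on this read-out higher numbers stand for higher lipophilicity and lower numbers for lower lipophilicity. Compound 1 (`COc1ccc(C2=NO[C@]3(C2)C(=O)O[C@@H]2[C@H]3CC[C@H](C)[C@]3(O)C=CC(=O)[C@@]23C)cc1`) gives 1.47, compound 2 (`Cc1cccc(C2=NO[C@]3(C2)C(=O)O[C@@H]2[C@H]3CC[C@H](C)[C@]3(O)C=CC(=O)[C@@]23C)c1`) gives 1.86, and compound 3 (`C[C@H]1CC[C@@H]2[C@@H](OC(=O)[C@]23CC(c2ccccc2)N(c2ccccc2)O3)[C@]2(C)C(=O)C=C[C@@]12O`) stands highest of the three at 3.19. Compound 4 (`C[C@H]1CC[C@@H]2[C@@H](OC(=O)[C@]23CC(c2ccccc2Cl)N(c2ccccc2)O3)[C@]2(C)C(=O)C=C[C@@]12O`) departs from compound 3 by chloro in place of hydrogen on an aromatic carbon, ortho to a large group. Among the measured compounds shown here, only one measured step offers any guide, a number 0.39 log units higher from compound 1 to compound 2 (beyond the scatter), which is modest and beyond the scatter. For the measured compounds named here, it involves different groups, and no measured pair adds chloro, so it is a rough guide to size only. A modest upward step in this assay is expected. The estimated step is a number 0.51 log units higher from compound 3 to compound 4 (beyond the scatter). Compound 4 is estimated at 3.7, with an expected range of 3.3 to 4.2.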

Compound 4, partition coefficient: 3.87
Compound 4: the middle estimate sits 0.17 log units below what was measured; the range from low to high includes it.
By their numbers in this assay, from the lowest: compound 1; then compound 2; then compound 3; then compound 4.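

In this assay, among the compounds shown here, phenyl to 2-chlorophenyl gives a number 0.68 log units higher from compound 3 to compound 4 (beyond the scatter), the first measured chloro step, on an aromatic carbon ortho to a large group. For the compounds shown here, the read-out thus still moves upward from compound 3, already the highest of the earlier compounds. Nothing at hand speaks to what sets the size of this step.

Going by these compounds, whether an amine or a carboxylic acid at this same position would move the number, and in which direction, stays open. This single pair also leaves open whether chloro gives a similar step on the core of compound 1.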